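The source may hold more compounds than are shown below. What is called first, only, known or untested is meant among the compounds shown, and "the series" means these compounds.

Compound 1 `Cc1ccc(-c2nc(N)c3cc(-c4ccccc4)sc3n2)o1` gives 520 nM in a functional assay on CHO-K1 cells for antagonist activity at adenosine receptor A1 (Homo sapiens), read by a beta-galactosidase reporter and cAMP accumulation, with stated times of 15 min and 6 h; on this read-out lower numbers stand for stronger inhibition and higher numbers for weaker inhibition. Compound 2 `Cc1ccc(-c2nc(N)c3cc(Cc4ccccc4Cl)sc3n2)o1` gives 26.1 nM. Compound 3 `Cc1ccc(-c2nc(N)c3cc(Cc4ccccc4F)sc3n2)o1` gives < 16 nM, which is a limit of this assay rather than a number.

Compound 3 therefore stands at the floor of the values shown, as the limit of < 16 nM in this assay, at which 1 of the 3 values shown sits, records, and the steps of an at least 32-fold lower number from compound 1 to compound 3 (1.51 log units; beyond the scatter) and an at least 1.6-fold lower number from compound 2 to compound 3 (0.21 log units; that floor lies within the scatter) lead to it. Compound 4 `Cc1csc(-c2nc(N)c3cc(Cc4ccccc4F)sc3n2)n1` differs from compound 3 by 4-methyl-1,3-thiazol-2-yl in place of 5-methylfuran-2-yl on an aromatic carbon. Among the compounds with values here, none of the measured steps touches this part of the shared core: the large steps of a 20-fold lower number from compound 1 to compound 2 (1.30 log units; beyond the scatter) and an at least 32-fold lower number from compound 1 to compound 3 (1.51 log units; beyond the scatter) concern the 2-chlorobenzyl and 2-fluorobenzyl groups, and an at least 1.6-fold lower number from compound 2 to compound 3 (0.21 log units; that floor lies within the scatter) swaps one halogen for another. No step beyond the scatter is expected from this change. Compound 4 is expected to give 15 nM, between 4 nM and 60 nM. The expected step is a step that the limit leaves unreadable from compound 3 to compound 4.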

Compound 4, inhibition constant: 28.6 nM
Compound 4: the middle estimate sits 1.9-fold (0.28 log units) below what was measured, within the range that was stated.
By their numbers in this assay, from the lowest: compounds 2 and 4 (each within the scatter of the next); then compound 1. At a limit, below all of these: compound 3.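

The other steps shown leave this position, between two ring nitrogen atoms, untouched. With 4-methyl-1,3-thiazol-2-yl in place of 5-methylfuran-2-yl, this assay gives an at least 1.7-fold higher number from compound 3 to compound 4 (0.25 log units; that floor lies within the scatter), so this swap shows no change beyond the scatter, though it does not rule one out. Compound 3 is recorded only as a limit, so the true size of the step cannot be read: the limit of < 16 nM in this assay, at which 1 of the 4 values shown sits.

On these data alone, what an amine or a longer alkyl chain would give at this position stays open. So does whether the same swap reads alike with 2-chlorobenzyl on the shared core.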